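Bombesin receptor subtype-3 agonists: ring replacement for the butyl chain

This account rests on a few compounds, and the source may have more. Where it says the series, first, only, none or still open, it means among the compounds named here.

Compound 1 `O=C(O)c1ccccc1-c1ccc(CCc2ncc(C3CCCCC3)[nH]2)cc1` gives 375 nM in an in vitro functional assay on cells for agonist activity at Bombesin receptor subtype-3 (Homo sapiens), read by luminescence and calcium flux; a higher number here means that more compound is needed for the effect, a lower number that less compound is needed. Compound 2 `CCCCc1cnc(CCc2ccc(-c3ccccc3C(=O)O)cc2)[nH]1` gives 2710 nM and holds the highest of the two numbers; the change between them, butyl in place of cyclohexyl on an aromatic carbon, reads a 7.2-fold higher number from compound 1 to compound 2 (0.86 log units; beyond the scatter). Compound 3 `O=C(O)c1ccccc1-c1ccc(CCc2ncc(Cc3cccc(F)c3F)[nH]2)cc1` differs from compound 2 by 2,3-difluorophenyl in place of propyl on a saturated chain carbon bound to an aromatic carbon. Among the measured compounds shown here, the only step at hand swaps the group on the same aromatic carbon, so it bears on this step only loosely: a ring replacing a chain there went with the lower number. For compound 3 the expectation is a lower number, a 3.0-fold lower number from compound 2 to compound 3 (0.48 log units; beyond the scatter), giving an estimate of 900 nM within 250 nM to 3500 nM.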

Compound 3, half-maximal effective concentration: 87 nM
The estimate for compound 3 lay 10-fold (1.01 log units) above the measured number; the measured number lies below the stated range.
By their numbers in this assay, from the lowest: compound 3; then compound 1; then compound 2.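

On this aromatic carbon, 2,3-difluorobenzyl improves on both earlier groups in this assay, against butyl (a 31-fold lower number from compound 2 to compound 3 (1.49 log units; beyond the scatter)) and against cyclohexyl (a 4.3-fold lower number from compound 1 to compound 3 (0.63 log units; beyond the scatter)). The presence of a ring therefore does not alone set the number here, since the two ring-bearing groups, cyclohexyl and 2,3-difluorobenzyl, also differ beyond the scatter. No measurement at hand explains either step.

As far as these compounds go, how an unsubstituted benzyl group would read remains open, so the share of the two fluorines in these steps is unknown. Also open, from the compounds shown here alone, is whether a methoxy group on that ring would hold the number.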